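Swapping a dimethoxyphenyl for a methoxypyridyl on the amine

The source may hold more compounds than are shown below. What is called first, only, known or untested is meant among the compounds shown, and "the series" means these compounds.

Of the compounds shown here, two sharing one core have been tested in a functional assay on BT-549 cells (Homo sapiens) for cytotoxicity, read by sulforhodamine B assay, with a stated time of 72 h; a higher number here means a weaker inhibitor, a lower number a stronger inhibitor. Compound 1 `CCS(=O)(=O)Nc1cc(-c2ccc3ncnc(Nc4ccc(OC)cc4)c3c2)cnc1OC` gives 1880 nM. Compound 2 `CCS(=O)(=O)Nc1cc(-c2ccc3ncnc(Nc4ccc(OC)c(OC)c4)c3c2)cnc1OC`, which differs only by a methoxy in place of a hydrogen on an aromatic carbon, gives 2590 nM. The step of a 1.4-fold higher number from compound 1 to compound 2 (0.14 log units; within the scatter) is small, so the two numbers cannot be told apart, and compound 2 holds the higher of the two numbers only within that scatter.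

Compound 3 `CCS(=O)(=O)Nc1cc(-c2ccc3ncnc(Nc4ccc(OC)nc4)c3c2)cnc1OC` is the next case. Its difference from compound 2 is 6-methoxypyridin-3-yl in place of 3,4-dimethoxyphenyl on a nitrogen on an aromatic ring. For the measured compounds named here, only one measured step, from compound 1 to compound 2, touches this position, and it shows that adding or removing a methoxy there changes little. No measured pair speaks to a ring nitrogen in place of a ring carbon at this position, so the data give no reason to expect a step beyond the scatter in this assay in either direction. Compound 3 is therefore estimated at 2000 nM, with a range from 800 nM to 5000 nM. That estimate means a step of a 1.3-fold lower number from compound 2 to compound 3 (0.11 log units; within the scatter), expected to stay within the scatter.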

Compound 3, half-maximal inhibitory concentration: 3490 nM
Compound 3: middle estimate off by 1.7-fold (0.24 log units), on the low side; low and high end bracket the measured number.
By their numbers in this assay, from the lowest: compounds 1, 2 and 3 (each within the scatter of the next).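

In this assay, putting 6-methoxypyridin-3-yl in place of 3,4-dimethoxyphenyl on a nitrogen on an aromatic ring gives a 1.3-fold higher number from compound 2 to compound 3 (0.13 log units; within the scatter) and the comparison with the simpler aryl group, 4-methoxyphenyl, gives a 1.9-fold higher number from compound 1 to compound 3 (0.27 log units; within the scatter) as the widest gap in the set. For the compounds shown here, this is the first look at an aromatic ring with a hetero atom on this amine, and even the widest gap stays within the scatter, so the three groups tried here cannot be told apart, whether the ring is carbon only or holds a nitrogen, and whether it carries one methoxy or two. The data offer no measured property that would explain these numbers, and none is needed for a set this close together.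

As far as these compounds go, what remains open is whether any group on this nitrogen can move the number beyond the scatter, for example a ring carrying a dimethylamino group or a carboxylic acid where the methoxy now stands. The three compounds also share the rest of their structure, so they say nothing about how the number responds to changes elsewhere on the shared core.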